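Adding a Third Methoxy Group to a Diamino Core

The source may hold more compounds than are shown below. What is called first, only, known or untested is meant among the compounds shown, and "the series" means these compounds.

Compound 1, `CCOC(=O)[C@H](CCC(=O)O)NC(=O)c1ccc(CNc2nc3cc(N)cc(N)c3nc2-c2ccccc2)cc1`, gives 93300 nM in a functional assay on SR cells (Homo sapiens) for inhibition, read by sulforhodamine B assay, with a stated time of 48 h; on this read-out higher numbers stand for lower toxicity in this test and lower numbers for higher toxicity in this test.
Compound 2, `Nc1cc(N)c2nc(-c3ccccc3)c(NCc3ccc(Cl)c(Cl)c3)nc2c1`, gives only a limit of < 100000 nM in this assay.
Compound 3, `COc1ccc(CNc2nc3cc(N)cc(N)c3nc2-c2ccccc2)cc1OC`, gives only a limit of < 100000 nM in this assay.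

Compound 3 thus stands at a limit of the test rather than at a number, and compound 1 alone yields a measured value, close to that limit. Among the compounds with values here, the one measured step, a step that the two limits leave unreadable from compound 2 to compound 3, cannot be sized, because the limit of < 100000 nM in this assay, at which 2 of the 3 values shown sit, leaves both ends unreadable. Compound 4, `COc1cc(CNc2nc3cc(N)cc(N)c3nc2-c2ccccc2)cc(OC)c1OC`, differs from compound 3 by methoxy in place of hydrogen on an aromatic carbon. Within the data shown here, no measured step therefore gives a readable size or direction, and no change beyond the scatter is expected in this assay. Compound 4 is expected to give 85000 nM, with a range from 30000 nM to 200000 nM, an estimated step that the limit leaves unreadable from compound 3 to compound 4.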

Compound 4, concentration lethal to 50% of the cells: < 50200 nM
Compound 4: only a limit was reported; the forecaster's own chance of this, stated with the estimate: 50%; middle value at least 1.6-fold (0.22 log units) from the limit.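

Compound 3 and compound 4 both give only limits in this assay, not numbers, so the step between them cannot be read. From the compounds shown here alone, whether methoxy in place of hydrogen on that aromatic carbon changes the read-out at all stays open.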